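A few compounds are considered here, and "the series" means these few. Any claim that something is new, unique, unknown or untested is made for them only; others in the source may bear on it.

Series notes, step from compound 2 to compound 3.

Of the compounds shown here, two have been measured in an assay on Sf9 cells for inhibition of protein deacetylase HDAC6 (Homo sapiens), read by fluorescence, with a stated time of 40 min, tested at 100 nM; on this read-out lower numbers stand for less inhibition and higher numbers for more inhibition at the one concentration tested (going by the name of the read-out). Compound 1 `Cc1ccccc1-c1nc(CNc2ccc(C(=O)NO)cc2)n(-c2ccccc2)n1` gives 53.2%. Within the data shown here, compound 2 `O=C(NO)c1ccc(NCc2nc(-c3ccc(Cl)c(Cl)c3)nn2-c2ccccc2)cc1` gives 34.5%, the lower of the two numbers; the only measured step, a number 18.7 percentage points lower from compound 1 to compound 2 (beyond the scatter), is the change of 3,4-dichlorophenyl in place of 2-methylphenyl on an aromatic carbon.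

Compound 3 `O=C(NO)c1ccc(NCc2nc(-c3ccsc3)nn2-c2ccccc2)cc1` is not yet measured. It differs from compound 2 in one place: thiophen-3-yl in place of 3,4-dichlorophenyl on an aromatic carbon. The group sits on an aromatic carbon of the five-membered aromatic ring with 3 nitrogen, between two ring nitrogen atoms, two ring bonds from the ring atom that bears a phenyl group.

Among the measured compounds shown here, no measured step exchanges a thiophen-3-yl for a phenyl-type group at this position, so the only guidance is that the two measured numbers differ by a number 18.7 percentage points lower from compound 1 to compound 2 (beyond the scatter) when the substitution pattern on this aryl group changes. The step to compound 3 is therefore expected to be of moderate size, a number 9.5 percentage points higher from compound 2 to compound 3 (within the scatter), with the direction uncertain. For compound 3 the estimate in this assay is 44%, with a range from 24% to 64%.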

Compound 3, a percentage reported as inhibition, at one concentration (the size of the read-out at that concentration, not a potency): 53.4%
Estimate against measurement, compound 3: 9.4 percentage points below; low and high end bracket the measured number.
By their numbers in this assay, from the lowest: compound 2; then compounds 1 and 3 (each within the scatter of the next).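

In this assay, among these compounds, the exchange at the aromatic carbon between two ring nitrogen atoms gives a number 18.9 percentage points higher from compound 2 to compound 3 (beyond the scatter), the first measured step at this position in which the aryl group is replaced by a five-membered aromatic ring with one hetero atom rather than by another phenyl-type group. Set against 2-methylphenyl, the thiophen-3-yl group gives a number 0.2 percentage points higher from compound 1 to compound 3 (within the scatter), so among these three compounds only compound 2, with 3,4-dichlorophenyl, stands apart, and the number in this assay is level for 2-methylphenyl and the smaller thiophen-3-yl, without a difference that can be read between them. Nothing available explains why 3,4-dichlorophenyl gives the lower number here.

Still open, going by these compounds, is whether an unsubstituted phenyl, a 4-chlorophenyl or a pyridin-3-yl group at this carbon would read like compound 1 and compound 3 or like compound 2, and what number a non-aromatic group such as cyclopropyl or an amine would give here. These numbers also describe inhibition at a single concentration, so how the compounds compare in potency remains undetermined.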